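Closing the Amine into a Ring: Compound 3

The source may report more compounds than this note shows. Statements on the series, on what has been measured and on what is new or still open speak of the compounds shown alone.

Compound 1, `CCCN(CCC)CCNc1nnc(-c2ccccc2)cc1C`, carries a dipropylamino group on a saturated chain carbon, two bonds along the chain from a nitrogen on an aromatic ring. In a functional assay on the whole organism with Mus musculus as the target (a higher number here means that more compound is needed for the effect, a lower number that less compound is needed), compound 1 gives only a limit of the assay, > 30 mg/kg, so where it truly stands is not known. Compound 2, `Cc1cc(-c2ccccc2)nnc1NCCCCN`, has 2-aminoethyl in place of that group. In this assay compound 2 likewise gives only a limit, > 50 mg/kg. The step that the two limits leave unreadable from compound 1 to compound 2 therefore cannot be read. Compound 3, `Cc1cc(-c2ccccc2)nnc1NCCN1CCCC1`, arises from compound 1 by the change (pyrrolidin-1-yl in place of dipropylamino on a saturated chain carbon, two bonds along the chain from a nitrogen on an aromatic ring). Among the compounds with values here, the single measured step at this position, a step that the two limits leave unreadable from compound 1 to compound 2, is unreadable, and both measured values sit at limits (the limit of > 30 mg/kg in this assay, at which 1 of the 2 values shown sits; (the limit of > 50 mg/kg in this assay, at which 1 of the 2 values shown sits)), so neither direction nor size can be drawn from the data. The step that the limit leaves unreadable from compound 1 to compound 3 is estimated to be small. Compound 3 is expected to give about 40 mg/kg, in the range 10 mg/kg to 120 mg/kg, quite possibly again reported only as a limit.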

Compound 3, dose for half-maximal effect: > 30 mg/kg
Compound 3 gave a limit, no number (the forecaster's own chance of this, stated with the estimate: 65%); the middle value is on the limit's open side.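

Compound 3 gives only a limit in this assay, as do compound 1 and compound 2, so no step among these three compounds can be read: the limit of > 30 mg/kg in this assay, at which 2 of the 3 values shown sit.

The compounds shown leave open where each of the three truly stands, and whether dipropylamino, 2-aminoethyl and pyrrolidin-1-yl differ at all in the dose needed.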